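Hydroxyphenyl placement on a shared pyridine-free core

The source may hold more compounds than are shown below. What is called first, only, known or untested is meant among the compounds shown, and "the series" means these compounds.

Measured so far:
compound 1, `Oc1ccc(-c2cc(-c3cccc(F)c3)cc(-c3ccc(O)cc3)n2)cc1`: > 50000 nM
compound 2, `Oc1ccc(-c2cc(-c3ccccc3C(F)(F)F)cc(-c3cccc(O)c3)n2)cc1`: 17400 nM

In a functional assay on HeLa cells (Homo sapiens) for inhibition (on this read-out lower numbers stand for stronger inhibition and higher numbers for weaker inhibition), compound 2 gives 17400 nM. Going by the values given here, this is the only actual number in the set; the remaining value is a limit. For compound 1 the read-out is > 50000 nM, which is a limit of the assay and not a number (the limit of > 50000 nM in this assay, at which 1 of the 2 values shown sits). Among the compounds with values here, compound 2 therefore stands as the single measured point, and no step between measured compounds exists to set a scale.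

Compound 3, `Oc1ccc(-c2cc(-c3ccccc3C(F)(F)F)cc(-c3ccc(O)cc3)n2)cc1`, is not yet measured. It differs from compound 2 by 4-hydroxyphenyl in place of 3-hydroxyphenyl on an aromatic carbon, so that compound 3 carries two 4-hydroxyphenyl groups, as compound 1 does. Compound 1 with two such groups reached only a limit, while compound 2 with one 3-hydroxyphenyl gave a number; nothing more connects them.

On that basis compound 3 is expected to move toward weaker inhibition by a modest step of a 1.7-fold higher number from compound 2 to compound 3 (0.24 log units; within the scatter), with a fair chance that only a limit is returned. The estimate for compound 3 in this assay is 30000 nM, within 12000 nM to 80000 nM.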

Compound 3, half-maximal inhibitory concentration: > 50000 nM
Compound 3: only a limit was reported; the forecaster's own chance of this, stated with the estimate: 40%; middle value at least 1.6-fold (0.22 log units) from the limit.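

In this assay, with the 2-(trifluoromethyl)phenyl group held fixed, 4-hydroxyphenyl in place of 3-hydroxyphenyl next to the ring nitrogen gives an at least 2.8-fold higher number from compound 2 to compound 3 (0.45 log units; beyond the scatter), so this exchange between two groups of identical atoms is enough on its own to produce a readable loss of inhibition at this position. Compound 1 and compound 3, each carrying two 4-hydroxyphenyl groups, both stand at a limit of the assay and not at a number: the limit of > 50000 nM in this assay, at which 2 of the 3 values shown sit. The step between these two, 2-(trifluoromethyl)phenyl in place of 3-fluorophenyl, cannot be read, so the contribution of that group remains undetermined.

Going by these compounds alone, how far compound 3 lies beyond its limit stays unknown, which leaves the full size of the step from the 3-hydroxyphenyl group open, and only one pair of compounds speaks to this position. Also open, going by these compounds, is whether an amine or a carboxylic acid in place of the hydroxyl on the 3-hydroxyphenyl group would hold, improve on or lose the activity of compound 2, which gives 17400 nM in this assay.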